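Replacing Fluoro with Hydroxy in a Growth Inhibitor

The source may report more compounds than this note shows. Statements on the series, on what has been measured and on what is new or still open speak of the compounds shown alone.

In a functional assay on COLO 205 cells (Homo sapiens) for inhibition, read by sulforhodamine B assay (a higher number here means a weaker inhibitor of growth, a lower number a stronger inhibitor of growth), compound 1 `Cc1ccc2[nH]c(-c3ccc(-c4ccc(-c5ccc(N(C)C)cc5)cc4)cc3)nc2c1` gives 9210 nM, whereas compound 2 `Cc1ccc2[nH]c(-c3ccc(-c4ccc(-c5ccc(F)cc5)cc4)cc3)nc2c1` gives 100000 nM. Compound 2 therefore has the higher of the two numbers and is the weaker growth inhibitor. The next structure, compound 3 `Cc1ccc2[nH]c(-c3ccc(-c4ccc(-c5ccc(O)cc5)cc4)cc3)nc2c1`, keeps the shared core and changes only the group that separates compound 1 from compound 2: hydroxy in place of fluoro on an aromatic carbon. Put simply, hydroxy stands in place of fluoro on an aromatic carbon, turning 4-fluorophenyl into 4-hydroxyphenyl.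

Going by the values given here, only one measured step bears on this change: an 11-fold higher number from compound 1 to compound 2 (1.04 log units; beyond the scatter), a large step beyond the scatter, with fluoro in place of dimethylamino. Among the compounds with values here, it shows that a swap at this group can shift the number substantially, but no compound with hydroxy has been measured, so the size of the new step remains uncertain. A move toward a lower number in this assay is expected, probably of a smaller size than the measured step. The estimated change is a 4.0-fold lower number from compound 2 to compound 3 (0.60 log units; beyond the scatter). For compound 3, the estimate is 25000 nM, with an expected range from 6000 nM to 100000 nM.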

Compound 3, concentration for 50% growth inhibition: 100000 nM
Compound 3: middle estimate off by 4.0-fold (0.60 log units), on the low side, within the range that was stated.
By their numbers in this assay, from the lowest: compound 1; then compounds 2 and 3 (each within the scatter of the next).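

In this assay, putting hydroxy in place of fluoro gives no change at the digits printed from compound 2 to compound 3 (within the scatter), so a group that brings a hydrogen-bond donor and acceptor, where fluoro counts none of either, leaves the number unchanged at this position. The comparison with dimethylamino now rests on two groups rather than one: an 11-fold higher number from compound 1 to compound 3 (1.04 log units; beyond the scatter), a step of the same size as the one already seen with fluoro, and among these three compounds only compound 1 stands apart, with the lower number. Nothing available here explains why dimethylamino differs from the other two groups.

As far as these compounds go, it remains open whether the lower number belongs to dimethylamino alone or extends to other amines, and a plain amino group or a methoxy group on the same aromatic carbon would help to separate these two possibilities. From the compounds shown here alone, it is also open whether a longer chain ending in an amine, or a carboxylic acid, at this position would move the number further from that of compound 3 than dimethylamino does.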